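Three Analogues at the Limit, a Fourth to Follow

The source may hold more compounds than are shown below. What is called first, only, known or untested is meant among the compounds shown, and "the series" means these compounds.

Compound 1, `COc1cc(OC(F)(F)F)cc(-c2ccc3c(c2)CC[C@H](CCc2nnn[nH]2)O3)c1F`, gives > 10000 nM in a functional assay on HEK293 cells for agonist activity at Free fatty acid receptor 1 (Homo sapiens), read by HTRF and inositol phosphate accumulation, with a stated time of 60 min; on this read-out higher numbers stand for an effect only at larger amounts of compound and lower numbers for an effect already at smaller amounts.
Compound 2, `COc1cc(O[C@H]2C[C@H](OC)C2)cc(-c2ccc3c(c2)CC[C@H]([C@@H]2C[C@H]2C(=O)O)O3)c1F`, gives > 10000 nM in this assay.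
Compound 3, `COc1cc(OC2CC2)cc(-c2ccc3c(c2)CC[C@H](CCc2nnn[nH]2)O3)c1F`, gives > 10000 nM in this assay.

Each of these three values is a limit of the assay rather than a measured number. Compound 3 therefore stands only at that limit, with no number of its own; the two other compounds shown stand at the same limit. Within the data shown here, the one change among the measured compounds, from a trifluoromethyl to a cyclopropyl on an oxygen on an aromatic ring, gives a step that the two limits leave unreadable from compound 1 to compound 3, a step that cannot be read because both ends lie at the limit of > 10000 nM in this assay, at which 3 of the 3 values shown sit.

Compound 4, `COc1cc(O[C@H]2C[C@H](OC)C2)cc(-c2ccc3c(c2)CC[C@H](CCc2nnn[nH]2)O3)c1F`, differs from compound 3 by 3-methoxycyclobutyl in place of cyclopropyl on an oxygen on an aromatic ring. Compound 2 already carries this 3-methoxycyclobutyl group on the same oxygen, paired with a different acidic group, and its value in this assay is a limit. No measured step bears directly on the change from compound 3 to compound 4, and none of the shown values gives a number to anchor a direction.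

Compound 4 is therefore expected to stay at the limit as well, with an expected step that the limit leaves unreadable from compound 3 to compound 4, and an estimated value of 15000 nM between 7000 nM and 40000 nM.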

Compound 4, half-maximal effective concentration: > 10000 nM
Compound 4: a limit, no number (the forecaster's own chance of this, stated with the estimate: 85%); the middle value is on the limit's open side.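

In this assay compound 4 gives > 10000 nM, which is a limit of the assay and not a number. No step among compound 1, compound 2, compound 3 and compound 4 can be read, because all of them sit at the same limit: the limit of > 10000 nM in this assay, at which 4 of the 4 values shown sit.

The compounds shown leave open how the trifluoromethyl, cyclopropyl and 3-methoxycyclobutyl groups compare in their effect on this receptor.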